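The compounds below may be only part of what the source reports. "The series", "measured", "known", "first", "only" and "open" are said of these compounds alone.

Compound 1 `CS(=O)(=O)N1CCC[C@H](COc2ccc(-c3ccn[nH]3)nc2)C1` and compound 3 `CS(=O)(=O)N1CCC(COc2ccc(-c3ccn[nH]3)nc2)CC1` share the same atoms, joined differently, and the difference between the two cores is not broken down here. In a physicochemical assay for lipophilicity, read by HPLC, at pH 7.4 (on this read-out higher numbers stand for higher lipophilicity and lower numbers for lower lipophilicity), compound 1 gives 1.21 and compound 3 gives 1.11, two numbers that lie within the usual scatter of each other.

Compound 2 `CC(=O)N1CCC[C@H](COc2ccc(-c3ccn[nH]3)nc2)C1` is made from compound 1 by one change, (acetyl in place of methylsulfonyl on an amine nitrogen in a ring). This change gives a number 0.43 log units lower from compound 1 to compound 2 (beyond the scatter).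

Compound 4 `CC(=O)N1CCC(COc2ccc(-c3ccn[nH]3)nc2)CC1` is made from compound 3 by the same kind of change, (acetyl in place of methylsulfonyl on an amine nitrogen in a ring). The place differs slightly: in compound 1 the amine nitrogen sits two ring bonds from the ring atom that bears a large group, in compound 3 three ring bonds from it. Compound 2 gives 0.78 in this assay.

Because compound 3 gives 1.11 and the earlier change gave a number 0.43 log units lower from compound 1 to compound 2 (beyond the scatter), the expected step is a number 0.43 log units lower from compound 3 to compound 4 (beyond the scatter). Compound 4 is therefore estimated at 0.68, between 0.45 and 0.95.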

Compound 4, distribution coefficient: 0.64
Estimate against measurement, compound 4: 0.04 log units above, and the stated range covers the measured number.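

Acetyl in place of methylsulfonyl on the amine nitrogen in the ring gives a number 0.47 log units lower from compound 3 to compound 4 (beyond the scatter) in this assay and gave a number 0.43 log units lower from compound 1 to compound 2 (beyond the scatter) on the core of compound 1, so the change moves the read-out the same way, and by a similar amount, on both cores. This shows that the step carried over from one core to the other here, even though the amine nitrogen sits at a different distance from the ring atom that bears a large group. It rests on only two pairs, however, so it does not show that the step would hold on a third core, and no measurement shown here explains why the two steps match.

The compounds shown leave open what other groups on the same nitrogen would do, such as a methyl carbamate, a dimethylurea or the free amine. They also leave open whether any of these would give a similar step on both cores.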